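Compound 3 and a Methoxy-Capped Chain

A few compounds are considered here, and "the series" means these few. Any claim that something is new, unique, unknown or untested is made for them only; others in the source may bear on it.

In an ADME assay on RAW264.7 cells (Mus musculus) for cytotoxicity, read by MTT assay, with a stated time of 24 h, in the absence of a further agent (a higher number here means a weaker inhibitor, a lower number a stronger inhibitor), compound 1 (`COc1cc(OC)c2c(c1)C(C(O)c1ccc(O)cc1)OC2=O`) gives > 40000 nM, which is a limit of the assay and not a number. Compound 2 (`CCCCCCOc1ccc(C(O)C2OC(=O)c3c(OC)cc(OC)cc32)cc1`), which carries a hexyl chain, gives > 40000 nM, and this too is a limit. Neither compound therefore has a readable number, and the two stand together at the limit of > 40000 nM in this assay, at which 2 of the 2 values shown sit.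

Compound 3 (`COCCCCOc1ccc(C(O)C2OC(=O)c3c(OC)cc(OC)cc32)cc1`) has not yet been measured. Its difference is methoxy in place of ethyl on a saturated chain carbon, four bonds along the chain from an oxygen on an aromatic ring. Cut one bond further out, the same change reads butyl to 2-methoxyethyl.

Among the measured compounds shown here, only one measured step bears on this change, and it gives no size to carry over: a step that the two limits leave unreadable from compound 1 to compound 2. With no size to go on, the expected step, a step that the limit leaves unreadable from compound 2 to compound 3, is none beyond the scatter, in either direction. In this assay compound 3 is expected at 45000 nM, with an estimated range of 25000 nM to 80000 nM, and it may well be reported only as a limit.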

Compound 3, half-maximal inhibitory concentration: > 40000 nM
Compound 3: a limit, no number (the forecaster's own chance of this, stated with the estimate: 85%); the middle value lies beyond the limit too.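

In this assay compound 3 gives > 40000 nM, which is a limit of the assay and not a number. No step among compound 1, compound 2 and compound 3 can be read, and all three stand together: the limit of > 40000 nM in this assay, at which 3 of the 3 values shown sit.

The compounds shown leave open how far beyond this limit each lies, and whether the hexyl or 4-methoxybutyl chain makes any difference.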